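Chain Changes on a Shared Core and Cell Tolerance

This account rests on a few compounds, and the source may have more. Where it says the series, first, only, none or still open, it means among the compounds named here.

Compound 1, `COC(=O)Cn1c(=O)c(C)cn([C@@H]2O[C@H](CO[Si](C)(C)C(C)(C)C)[C@@]3(OS(=O)(=O)C=C3N)[C@H]2O[Si](C)(C)C(C)(C)C)c1=O`: in a functional assay on CCRF-CEM cells (Homo sapiens) (a higher number here means that more compound is tolerated, a lower number that less compound is tolerated), compound 1 gives > 152000 nM, which is a limit of the assay and not a number.
Compound 2, `CCOC(=O)CCCCCn1c(=O)c(C)cn([C@@H]2O[C@H](CO[Si](C)(C)C(C)(C)C)[C@@]3(OS(=O)(=O)C=C3N)[C@H]2O[Si](C)(C)C(C)(C)C)c1=O`: in this assay compound 2 gives 40600 nM.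

Among the measured compounds shown here, compound 2 holds the only actual number; the other value is a limit (the limit of > 152000 nM in this assay, at which 1 of the 2 values shown sits). For the measured compounds named here, the one measured step, an at least 3.7-fold lower number from compound 1 to compound 2 (0.57 log units; beyond the scatter), replaced one ester-bearing chain on the same nitrogen with a longer one and lowered the number. Compound 3, `Cc1cn([C@@H]2O[C@H](CO[Si](C)(C)C(C)(C)C)[C@@]3(OS(=O)(=O)C=C3N)[C@H]2O[Si](C)(C)C(C)(C)C)c(=O)n(CCCN(C)C)c1=O`, again alters that chain: dimethylamino in place of 2-(ethoxycarbonyl)ethyl on a saturated chain carbon, three bonds along the chain from an aromatic nitrogen. This change is of a different kind from the measured one, so no direct guide exists; the measured step only shows that this chain matters. A number close to compound 2, within the scatter, is the expectation, and compound 3 is estimated at 30000 nM, in the range 8000 nM to 120000 nM, meaning an expected 1.4-fold lower number from compound 2 to compound 3 (0.13 log units; within the scatter).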

Compound 3, half-maximal cytotoxic concentration: 10400 nM
Estimate against measurement, compound 3: 2.9-fold (0.46 log units) above; the range from low to high includes it.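

Until now only ester-bearing chains stood on this nitrogen. Putting dimethylamino in place of 2-(ethoxycarbonyl)ethyl, three bonds along the chain from an aromatic nitrogen, gives a 3.9-fold lower number from compound 2 to compound 3 (0.59 log units; beyond the scatter) in this assay, so an ester at the end of the chain is not required for a lower number on the shared core. Set against the short ester chain, the change reads as an at least 14-fold lower number from compound 1 to compound 3 (1.16 log units; beyond the scatter), and the size of this step rests on a limit of the assay for compound 1, not on a number: the limit of > 152000 nM in this assay, at which 1 of the 3 values shown sits.

The compounds shown leave open whether the amine at the chain end or the shorter chain accounts for the step, for the two differ together in this pair. A carboxylic acid at the chain end, or a longer chain ending in dimethylamino, would be needed to pull these two apart.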